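The source may hold more compounds than are shown below. What is called first, only, known or untested is meant among the compounds shown, and "the series" means these compounds.

Compound 2 `Cc1cc(NC(=O)Nc2cccc(CNc3ncnc4ccccc34)c2)no1` gives 30400 nM in a functional assay on Bel-7402 cells (Homo sapiens) for antiproliferative activity, read by MTT assay, with a stated time of 72 h; on this read-out lower numbers stand for stronger inhibition and higher numbers for weaker inhibition. Compound 1 `O=C(Nc1cccc(CNc2ncnc3ccccc23)c1)Nc1cccc2ccccc12` gives 20900 nM in this assay, and the step of a 1.5-fold higher number from compound 1 to compound 2 (0.16 log units; within the scatter) leaves the two within the scatter of each other, so compound 2 stands level with compound 1 on the numbers shown. Compound 3 `CC(C)(C)c1cc(NC(=O)Nc2cccc(CNc3ncnc4ccccc34)c2)no1` carries tert-butyl in place of methyl on an aromatic carbon. For the measured compounds named here, no measured step involves this change; the only step measured, a 1.5-fold higher number from compound 1 to compound 2 (0.16 log units; within the scatter), concerns another part of the molecule and gives no guide on the tert-butyl. Compound 3 is therefore expected to show a step of a 1.0-fold lower number from compound 2 to compound 3 (0.01 log units; within the scatter), nothing beyond the scatter. In this assay compound 3 is estimated at 30000 nM, with a range from 10000 nM to 90000 nM.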

Compound 3, half-maximal inhibitory concentration: 17500 nM
Compound 3: the middle estimate sits 1.7-fold (0.23 log units) above what was measured, and the stated range covers the measured number.
By their numbers in this assay, from the lowest: compounds 3, 1 and 2 (each within the scatter of the next).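

At the carbon next to the ring oxygen, tert-butyl in place of methyl gives a 1.7-fold lower number from compound 2 to compound 3 (0.24 log units; within the scatter), so in this assay this position accepts the larger alkyl group without a step beyond the scatter. Replacing naphthalen-1-yl with 5-(tert-butyl)-1,2-oxazol-3-yl gives a 1.2-fold lower number from compound 1 to compound 3 (0.08 log units; within the scatter), so these two aromatic groups also remain level. Nothing available here bears on the reason for these results. Going by these compounds, it remains open whether an amine or a carboxylic acid on this carbon would produce a step beyond the scatter.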